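A few compounds are considered here, and "the series" means these few. Any claim that something is new, unique, unknown or untested is made for them only; others in the source may bear on it.

Measured so far in an ADME assay on KB cells (Homo sapiens) for cytotoxicity, with a stated time of 48 h; on this read-out higher numbers stand for weaker inhibition and lower numbers for stronger inhibition:

- Compound 1 `CC1=CCC[C@](C)(CC/C(C)=C/CC2=C(O)C(=O)C=C(N[C@@H](CO)C(=O)O)C2=O)[C@@H]1C` reads > 10 ug/mL (a limit)
- Compound 2 `CC1=CCC[C@](C)(CC/C(C)=C/CC2=C(O)C(=O)C=C(N[C@@H](C(=O)O)C(C)C)C2=O)[C@@H]1C` reads > 10 ug/mL (a limit)
- Compound 3 `C=C1[C@H](C)CCC[C@]1(C)CC/C(C)=C/CC1=C(O)C(=O)C=C(N[C@H](C(=O)O)C(C)C)C1=O` reads > 10 ug/mL (a limit)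

Compound 3 thus stands at > 10 ug/mL as a limit and not a number. Compound 4 `CC1=CCC[C@](C)(CC/C(C)=C/CC2=C(O)C(=O)C=C(N[C@H](C(=O)O)C(C)C)C2=O)[C@@H]1C` has the same atoms joined differently: a group of 9 heavy atoms (9 carbon; one six-membered non-aromatic ring of carbon only) in place of a group of 9 heavy atoms (9 carbon; one six-membered non-aromatic ring of carbon only), on a saturated chain carbon, two bonds along the chain from a double-bonded chain carbon and the group that enters is 1,2,3-trimethylcyclohex-3-en-1-yl. Among the compounds with values here, the only measured step is a step that the two limits leave unreadable from compound 1 to compound 2 and it concerns the group on the amine nitrogen, so it gives no size for this change. The remaining guide is the limit of > 10 ug/mL in this assay, at which 3 of the 3 values shown sit, and it offers no number. No step beyond the scatter and no direction can therefore be forecast in this assay with any confidence. The estimated step is a step that the limit leaves unreadable from compound 3 to compound 4 and it is an expectation only. For compound 4 the expected value is 15 ug/mL with an estimated range from 8 ug/mL to 40 ug/mL and a report as a limit is the likelier outcome.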

Compound 4, half-maximal inhibitory concentration: > 10 ug/mL
Compound 4: only a limit was reported (the forecaster's own chance of this, stated with the estimate: 80%); the middle value lies beyond the limit too.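

In this assay compound 4 gives > 10 ug/mL as a limit. Within the data shown here, no step from compound 1, compound 2 or compound 3 to compound 4 can be read. The compounds shown leave open whether the configuration, the ring change or the amine group alters inhibition at all: the limit of > 10 ug/mL in this assay, at which 4 of the 4 values shown sit.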